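This account rests on a few compounds, and the source may have more. Where it says the series, first, only, none or still open, it means among the compounds named here.

Compound 1 `O=C(Nc1ccc(Cl)c(C(F)(F)F)c1)N[C@H]1CCN(c2ccc3nncn3n2)C1` and compound 2 `O=C(Nc1ccc(Cl)c(C(F)(F)F)c1)N[C@H]1CCN(c2ccnc(NC3CC3)n2)C1` share a urea-linked core and differ only in the group attached to the ring amine nitrogen. In an assay on a protein complex for displacement of a labelled ligand from CDK8/Cyclin C (Homo sapiens), read by TR-FRET, with a stated time of 1 h (on this read-out lower numbers stand for stronger inhibition and higher numbers for weaker inhibition), compound 1 gives 4.2 nM, while compound 2 gives 20.3 nM, so the step of a 4.8-fold higher number from compound 1 to compound 2 (0.68 log units; beyond the scatter) runs toward weaker inhibition. Compound 2 thus has the highest number of the two measured; compound 1 is the nearest and sits clearly lower.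

Compound 3 `CCNc1nccc(N2CC[C@H](NC(=O)Nc3ccc(Cl)c(C(F)(F)F)c3)C2)n1` keeps the core of compound 2 and changes one detail: ethyl in place of cyclopropyl on a nitrogen on an aromatic ring. Among the measured compounds shown here, no measured pair shows this same cyclopropylamino to ethylamino exchange, and the single step from compound 1 to compound 2 concerns a different part of the molecule, so no direct guide exists. A small change of this kind is expected to move the number little, perhaps slightly toward weaker inhibition, as a 1.4-fold higher number from compound 2 to compound 3 (0.14 log units; within the scatter). Compound 3 is therefore estimated at 28 nM, with a range from 10 nM to 70 nM.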

Compound 3, half-maximal inhibitory concentration in the CDK8/Cyclin C assay: 8.9 nM
Compound 3: middle estimate off by 3.1-fold (0.50 log units), on the high side; the measured number lies below the stated range.
By their numbers in the CDK8/Cyclin C assay, from the lowest: compound 1; then compound 3; then compound 2.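

In the CDK8/Cyclin C assay the step of a 2.3-fold lower number from compound 2 to compound 3 (0.36 log units; beyond the scatter) shows that this nitrogen substituent matters: even the small exchange of cyclopropyl for ethyl gives stronger inhibition. In the CDK8/Cyclin C assay the step of a 2.1-fold higher number from compound 1 to compound 3 (0.33 log units; beyond the scatter) shows that ethylamino narrows the gap to compound 1 but does not close it. In a physicochemical assay for solubility, measured as kinetic solubility (on this read-out lower numbers stand for lower solubility and higher numbers for higher solubility), compound 2 gives 49200 nM and compound 3 gives 29900 nM for solubility, and the step of a 1.6-fold lower number from compound 2 to compound 3 (0.22 log units; within the scatter) lies within the scatter, so the two cannot be told apart on this measure.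

Nothing available here gives a reason for the shift in inhibition. Still open, from the compounds shown here alone, is how a methyl group or a longer chain such as propyl on this nitrogen would compare with ethyl.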